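A few compounds are considered here, and "the series" means these few. Any claim that something is new, unique, unknown or untested is made for them only; others in the source may bear on it.

In a physicochemical assay for solubility, read by HPLC, with a stated time of 20 min (a higher number here means a more soluble compound, a lower number a less soluble compound), compound 1 `NC1CCC(CN2CCN(c3cc(=O)c4cc(C(F)(F)F)cc([N+](=O)[O-])c4s3)CC2)CC1` gives 43.9 ug/mL. Compound 2 `O=c1cc(N2CCN(CC3CCCCC3)CC2)sc2c([N+](=O)[O-])cc(C(F)(F)F)cc12` gives < 0.1 ug/mL, which is a limit of the assay and not a number. Its position is therefore only (the limit of < 0.1 ug/mL in this assay, at which 1 of the 2 values shown sits).

Compound 3 `O=c1cc(N2CCN(CC3CCC(O)CC3)CC2)sc2c([N+](=O)[O-])cc(C(F)(F)F)cc12` follows from compound 2 by hydroxy in place of hydrogen on a saturated ring carbon, that is, cyclohexylmethyl to (4-hydroxycyclohexyl)methyl. Among the measured compounds shown here, the one measured step that bears on this is an at least 430-fold lower number from compound 1 to compound 2 (2.64 log units; beyond the scatter), where hydrogen stands in place of amino on a saturated ring carbon. Read backwards, that large step points to a higher number when the hydrogen gives way to a group with a heteroatom. However, hydroxy is not amino, and one step is thin evidence, so only part of that size is expected to carry over. The expected change in this assay is an at least 7.0-fold higher number from compound 2 to compound 3 (0.84 log units; beyond the scatter), upward and probably beyond the scatter. For compound 3 the estimate is 0.7 ug/mL, with an expected range of 0.1 ug/mL to 6 ug/mL.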

Compound 3, solubility: 8.3 ug/mL
The estimate for compound 3 lay 12-fold (1.07 log units) below the measured number; the measured number lies above the stated range.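

In this assay, a high number at this saturated ring carbon is not tied to amino alone: hydroxy in place of hydrogen gives an at least 83-fold higher number from compound 2 to compound 3 (1.91 log units; beyond the scatter) on the same cyclohexylmethyl group. The compound 2 end of that step is a limit of the assay and not a number: the limit of < 0.1 ug/mL in this assay, at which 1 of the 3 values shown sits. Hydroxy in place of amino gives a 5.3-fold lower number from compound 1 to compound 3 (0.72 log units; beyond the scatter) and so the two groups do not read the same at this place, though this step is modest and the step from hydrogen is large.

Going by these compounds, it remains open how other groups on this ring carbon would read, such as a carboxylic acid or a methoxy group. On these data alone, it is also open whether the hydroxy step keeps its size when a longer chain replaces the methylene of (4-hydroxycyclohexyl)methyl.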